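The source may hold more compounds than are shown below. What is called first, only, known or untested is meant among the compounds shown, and "the series" means these compounds.

Compound 1 `CCCCNc1nc(N)c2nc(O)n(Cc3ccccc3)c2n1` is the reference point of this set. In a functional assay (spleen, spleen) for activation, with Mus musculus as the target (a lower number here means that less compound is needed, a higher number that more compound is needed for the effect), compound 1 gives 1 uM, the lowest of the two numbers that were reported. Its nearest neighbour is compound 3 `Nc1ncnc2c1nc(O)n2Cc1cccc2ccccc12`, which in this assay gives 10 uM, a gap that lies beyond the scatter of repeated measurements. Compound 2 `Nc1ncnc2c1nc(Cl)n2Cc1ccccc1` yields only a limit in this assay, > 10 uM, and so stands apart from the two numbers; that is the limit of > 10 uM in this assay, at which 1 of the 3 values shown sits.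

The account now turns to compound 4 `CCCc1nc(N)c2nc(O)n(Cc3ccccc3)c2n1`, which has not yet been measured in this assay. Relative to compound 1 the change is propyl in place of butylamino on an aromatic carbon. Within the data shown here, no measured step in this set connects two compounds that differ in only one place, so the size of the step from compound 1 to compound 4 is an estimate: the writer expects a modest rise in the number, a 3.0-fold higher number from compound 1 to compound 4 (0.48 log units; beyond the scatter), rather than none beyond the scatter. Compound 4 is accordingly expected to give 3 uM in this assay, within a range from 1 uM to 10 uM.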

Compound 4, minimum effective concentration: 1 uM
Estimate against measurement, compound 4: 3.0-fold (0.48 log units) above; measured number inside the range.
By their numbers in this assay, from the lowest: compounds 1 and 4 (each within the scatter of the next); then compound 3.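

In this assay, among these compounds, putting propyl in place of butylamino, on the aromatic carbon between two ring nitrogen atoms, shows no change at the digits printed from compound 1 to compound 4 (within the scatter), and this is the first step in the set between two compounds that differ in one place. It shows that the hydrogen-bond donor and acceptor counted on butylamino, which propyl lacks, are not needed at this position to keep the number in this assay at this level. Nothing given here accounts for this outcome.

The compounds shown leave open whether a longer chain such as hexyl, a tertiary amine such as dimethylamino, or a carboxylic acid at this position would keep the number in this assay. They also leave open how far this tolerance extends to chains shorter than propyl, such as methyl.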